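Swapping Thiazole for Thiadiazole on an Inactive Scaffold

The compounds below may be only part of what the source reports. "The series", "measured", "known", "first", "only" and "open" are said of these compounds alone.

Of the compounds shown here, three have been tested in an assay for inhibition of proto-oncogene tyrosine-protein kinase ROS (Homo sapiens), read by Z'-LYTE (a lower number here means a stronger inhibitor, a higher number a weaker inhibitor), so far. Compound 1 `CC(Oc1cccnc1Nc1cnn(C)c1)c1cccc(C(=O)NCc2ccc(OC(F)(F)F)cc2)c1` carries a 4-(trifluoromethoxy)phenyl group on the amide side of the molecule. In this assay compound 1 gives > 10000 nM, which is a limit of the assay rather than a number. Compound 2 `CC(Oc1cccnc1Nc1cnn(C)c1)c1cccc(C(=O)NCc2ccc(F)c(Cl)c2)c1` differs from it in that one place. In this assay compound 2 gives > 10000 nM, again a limit. The step that the two limits leave unreadable from compound 1 to compound 2 therefore cannot be read from the two values. Compound 3 `Cc1ccc(CNC(=O)c2cccc(C(C)Oc3cccnc3Nc3nccs3)c2)cc1` has a different amide-side group and a 1,3-thiazol-2-yl ring on the aromatic nitrogen of the shared core. In this assay compound 3 gives > 10000 nM, which is also a limit. Compound 3 thus stands at the edge of what the assay can report, as described by the limit of > 10000 nM in this assay, at which 3 of the 3 values shown sit. Compound 4 `Cc1ccc(CNC(=O)c2cccc(C(C)Oc3cccnc3Nc3nncs3)c2)cc1` is the compound still to be measured, and the change from compound 3 is 1,3,4-thiadiazol-2-yl in place of 1,3-thiazol-2-yl on a nitrogen on an aromatic ring. For the measured compounds named here, no measured step bears on this change, since the only known step is unreadable. The expectation is that compound 4 stays at the limit, with an estimated step that the limit leaves unreadable from compound 3 to compound 4 that is no change beyond the scatter. The estimate for compound 4 is 20000 nM, expected to range from 5000 nM to 100000 nM.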

Compound 4, half-maximal inhibitory concentration: > 10000 nM
Compound 4 ended at the assay's limit (the forecaster's own chance of this, stated with the estimate: 85%); the middle value does not contradict the limit.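

Compound 3 and compound 4 both sit at a limit of the assay rather than at a number, so the effect of the swap of 1,3-thiazol-2-yl for 1,3,4-thiadiazol-2-yl cannot be read: the limit of > 10000 nM in this assay, at which 4 of the 4 values shown sit. The compounds shown leave open whether this assay can return a measured number for any compound built on this shared core.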